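From 2-hydroxyphenyl to 3-hydroxybenzyl on the amide nitrogen

The source may report more compounds than this note shows. Statements on the series, on what has been measured and on what is new or still open speak of the compounds shown alone.

Values measured in an ADME assay on MT4 cells (Homo sapiens) for cytotoxicity, read by MTT assay (on this read-out higher numbers stand for lower toxicity in this test and lower numbers for higher toxicity in this test), for three compounds
compound 1 `Cc1cc(C)cc(S(=O)(=O)c2c(C(=O)Nc3ccccc3O)[nH]c3ccc(Cl)cc23)c1` gives 19700 nM
compound 2 `Cc1cc(C)cc(S(=O)(=O)c2c(C(=O)NCc3ccccc3O)[nH]c3ccc(Cl)cc23)c1` gives 23800 nM
compound 3 `Cc1cc(C)cc(S(=O)(=O)c2c(C(=O)NCc3ccccc3N)[nH]c3ccc(Cl)cc23)c1` gives 46200 nM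

Compound 1 stands at the low end of these numbers, but not alone. Within the data shown here, the move to 2-hydroxybenzyl gives a 1.2-fold higher number from compound 1 to compound 2 (0.08 log units; within the scatter), whereas the move to 2-aminobenzyl gives a 2.3-fold higher number from compound 1 to compound 3 (0.37 log units; beyond the scatter), the only modest change seen so far. Amino in place of hydroxy on an aromatic carbon gives a 1.9-fold higher number from compound 2 to compound 3 (0.29 log units; within the scatter).

The next compound to be tested is compound 4 `Cc1cc(C)cc(S(=O)(=O)c2c(C(=O)NCc3cccc(O)c3)[nH]c3ccc(Cl)cc23)c1`. It carries 3-hydroxybenzyl in place of 2-hydroxyphenyl on an amide-type nitrogen. The closest guide is compound 2, which also has a hydroxybenzyl group and shows a 1.2-fold higher number from compound 1 to compound 2 (0.08 log units; within the scatter). Compound 3 sets the wider edge of the series with a 2.3-fold higher number from compound 1 to compound 3 (0.37 log units; beyond the scatter). Among the measured compounds shown here, no measured compound carries 3-hydroxybenzyl, so the data cannot say what that particular group does in this assay on its own.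

The expected change is small and no larger than the scatter, estimated as a 1.3-fold higher number from compound 1 to compound 4 (0.12 log units; within the scatter) in the direction of a higher number. For compound 4 the estimated value is 26000 nM, within an expected range of 13000 nM to 50000 nM in this assay and no tighter.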

Compound 4, half-maximal cytotoxic concentration: 27000 nM
For compound 4 the middle estimate is 1.0-fold (0.02 log units) below the measured one; the range from low to high includes it.
By their numbers in this assay, from the lowest: compounds 1, 2, 4 and 3 (each within the scatter of the next, the first and the last beyond it).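

In this assay the 3-hydroxybenzyl group on the amide-type nitrogen leaves the number within the scatter of 2-hydroxyphenyl (a 1.4-fold higher number from compound 1 to compound 4 (0.14 log units; within the scatter)). Placing the hydroxy-bearing ring as 3-hydroxyphenyl rather than 2-hydroxyphenyl on the saturated chain carbon bound to an amide-type nitrogen also stays within the scatter (a 1.1-fold higher number from compound 2 to compound 4 (0.05 log units; within the scatter)), as does the exchange of 2-aminophenyl for 3-hydroxyphenyl on that carbon (a 1.7-fold lower number from compound 3 to compound 4 (0.23 log units; within the scatter)), so this new group cannot be told apart from any of the three earlier groups on this read-out, and the one gap beyond the scatter remains the 2-aminobenzyl against 2-hydroxyphenyl pair. No measurement shown here offers an explanation for these numbers.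

Still open, from the compounds shown here alone, is whether 4-hydroxybenzyl, 3-aminobenzyl or a longer chain such as 2-(3-hydroxyphenyl)ethyl on the same nitrogen would stay in this narrow band. The compounds shown also leave open what a methoxy group in place of the hydroxy of 3-hydroxybenzyl would do to the number.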